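The source may hold more compounds than are shown below. What is called first, only, known or untested is meant among the compounds shown, and "the series" means these compounds.

Of the compounds shown here, three of a shared core have been measured in a physicochemical assay for solubility, at pH 7 (on this read-out lower numbers stand for lower solubility and higher numbers for higher solubility), and a fourth awaits its turn. Compound 1 `CC1(C)c2[nH]nc(NC(=O)c3ccc(F)cc3)c2CN1C(=O)C1CCN(C2CC2)CC1` reaches the upper limit of the assay, and its reading of > 225000 nM is a limit rather than a number. Compound 2 `CN1CCC(C(=O)N2Cc3c(NC(=O)Nc4cccc(F)c4)n[nH]c3C2(C)C)CC1` likewise sits at that limit, its value of > 225000 nM being a limit and not a number. Compound 3 `CC(C)(C)C(=O)N1Cc2c(NC(=O)c3cccnc3)n[nH]c2C1(C)C` gives a real number, 207000 nM, in this assay. So where compound 2 stands is simply at the ceiling of what the assay reports, which it shares with one other compound: the limit of > 225000 nM in this assay, at which 2 of the 3 values shown sit.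

Compound 4 `CN1CCC(C(=O)N2Cc3c(NC(=O)c4cccs4)n[nH]c3C2(C)C)CC1` is the unmeasured one, and it differs from compound 2 in one place (thiophen-2-yl in place of (3-fluorophenyl)amino on a carbonyl carbon). The basic methylpiperidine part is kept unchanged. Within the data shown here, no step between two measured compounds is available to show what this kind of change does to solubility, so the expectation rests only on the picture the three readings give, in which every value stands near or at the top of the scale. The step from compound 2 to compound 4 is expected to be an at least 1.1-fold lower number from compound 2 to compound 4 (0.05 log units; that floor lies within the scatter), that is, nothing beyond the usual scatter, with the outcome most likely again a limit. Compound 4 is therefore expected to show about 200000 nM, with a likely range from 100000 nM to 225000 nM.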

Compound 4, solubility: 155000 nM
Beside the measured number, compound 4's estimate is 1.3-fold (0.11 log units) above it, within the range that was stated.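

In this assay, among these compounds, this is the only readable step at this place, the carbonyl carbon that carries the changing group, and it is an at least 1.4-fold lower number from compound 2 to compound 4 (0.16 log units; that floor lies within the scatter). The change replaces a six-membered aromatic ring of carbon only, joined through an amino link that holds a hydrogen-bond donor, with a five-membered aromatic ring with 1 hetero atom, sulfur, joined directly, while the methylpiperidine part stays the same. The true size of the step cannot be told, and neither can whether it goes beyond the usual scatter, because compound 2 has only a limit and no number of its own: the limit of > 225000 nM in this assay, at which 2 of the 4 values shown sit.

A single change here swaps both the ring and the amino link, so the compounds shown do not separate the two. From the compounds shown here alone, a (thiophen-2-yl)amino group on the same carbonyl carbon would keep the link and change only the ring, while a plain methyl group there would remove the ring altogether, and both remain open in this assay.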